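Halogen exchange on the aryl ketone: chloro to bromo

The compounds below may be only part of what the source reports. "The series", "measured", "known", "first", "only" and "open" are said of these compounds alone.

Compound 1 `COC(=O)c1cc(-c2cccc(NC(=O)c3ccc(/C=C/C(=O)c4ccc(C)c(F)c4)cc3)c2)on1` and compound 2 `COC(=O)c1cc(-c2cccc(NC(=O)c3ccc(/C=C/C(=O)c4cccc(Cl)c4)cc3)c2)on1` share one core. In an ADME assay on Vero cells (Chlorocebus sabaeus) for cytotoxicity, read by MTT assay, with a stated time of 72 h (on this read-out higher numbers stand for lower toxicity in this test and lower numbers for higher toxicity in this test), compound 1 gives only a limit, > 50 ug/mL. In this assay compound 2 likewise gives only a limit, > 2.5 ug/mL. Compound 1 sits at the limit of > 50 ug/mL in this assay, at which 1 of the 2 values shown sits. Compound 2 sits at the limit of > 2.5 ug/mL in this assay, at which 1 of the 2 values shown sits. The step that the two limits leave unreadable from compound 1 to compound 2 is therefore unreadable. Compound 3 `COC(=O)c1cc(-c2cccc(NC(=O)c3ccc(/C=C/C(=O)c4cccc(Br)c4)cc3)c2)on1` follows from compound 2 by bromo in place of chloro on an aromatic carbon. No measured step of this kind exists, and the one step shown gives no size. Compound 3 is expected to give about 30 ug/mL, between 5 ug/mL and 100 ug/mL, an expected step that the limit leaves unreadable from compound 2 to compound 3 of no size beyond the scatter.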

Compound 3, half-maximal cytotoxic concentration: > 100 ug/mL
Compound 3: a limit, no number; the forecaster's own chance of this, stated with the estimate: 60%; middle value at least 3.3-fold (0.52 log units) away from the limit.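

Among these compounds, compound 1, compound 2 and compound 3 each give only a limit in this assay, so no step among them can be read. Going by these compounds, whether bromo in place of chloro changes the read-out at all remains open.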